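A few compounds are considered here, and "the series" means these few. Any claim that something is new, unique, unknown or untested is made for them only; others in the source may bear on it.

Measured compounds:
Compound 1 `COc1ccc(/C=C2\C(=O)N(Cc3cn([C@@H]4O[C@H](COC(C)=O)[C@@H](OC(C)=O)[C@H](OC(C)=O)[C@H]4OC(C)=O)nn3)c3ccccc32)cc1OC` gives 23300 nM in a functional assay on A549 cells (Homo sapiens) for cytotoxicity, read by sulforhodamine B assay, with a stated time of 48 h; on this read-out lower numbers stand for stronger inhibition and higher numbers for weaker inhibition.
Compound 2 `CC(=O)OC[C@H]1O[C@@H](n2cc(CN3C(=O)/C(=C\c4ccc(N(C)C)cc4)c4ccccc43)nn2)[C@H](OC(C)=O)[C@@H](OC(C)=O)[C@@H]1OC(C)=O` gives 17700 nM in this assay.
Compound 3 `CC(=O)OC[C@H]1O[C@@H](n2cc(CN3C(=O)/C(=C/c4ccc(N(C)C)cc4)c4ccccc43)nn2)[C@H](OC(C)=O)[C@@H](OC(C)=O)[C@@H]1OC(C)=O` gives 19400 nM in this assay.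

Going by the values given here, compound 2 has the lowest of the three numbers, but all three sit close together: the step of a 1.1-fold higher number from compound 2 to compound 3 (0.04 log units; within the scatter) and the step of a 1.3-fold lower number from compound 1 to compound 2 (0.12 log units; within the scatter) are both within the usual scatter, so no compound can be called more active than another. The closeness of compounds 2 and 3 fits the fact that they differ only in how the double bond is drawn (the fact that compounds 2 and 3 differ only in the configuration as drawn).

Compound 4 `CCC/C=C1\C(=O)N(Cc2cn([C@@H]3O[C@H](COC(C)=O)[C@@H](OC(C)=O)[C@H](OC(C)=O)[C@H]3OC(C)=O)nn2)c2ccccc21` differs from compound 2 by propyl in place of 4-(dimethylamino)phenyl on a double-bonded chain carbon bound to a double-bonded ring carbon. Among the compounds with values here, the only measured step at this place is a 1.3-fold lower number from compound 1 to compound 2 (0.12 log units; within the scatter), where one aromatic ring was swapped for another and the number barely moved. Within the data shown here, no measured step removes the ring and leaves a short chain, so the expectation rests on thin ground. Compound 4 is expected to give a somewhat higher number, the estimated step being a 1.8-fold higher number from compound 2 to compound 4 (0.26 log units; within the scatter). The estimate for compound 4 is 32000 nM, with a range from 12000 nM to 85000 nM.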

Compound 4, half-maximal inhibitory concentration: 40400 nM
Compound 4: middle estimate off by 1.3-fold (0.10 log units), on the low side, within the range that was stated.
By their numbers in this assay, from the lowest: compounds 2, 3, 1 and 4 (each within the scatter of the next, the first and the last beyond it).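

Compounds 1, 2 and 3 only compared one aromatic ring with another at this place, and their numbers in this assay stayed within the scatter of each other. Compound 4 has no ring there, only a propyl chain, and this shows that such a chain can be carried on the double-bonded chain carbon with activity still measurable in the same range. The outcome depends on the comparison: a 2.3-fold higher number from compound 2 to compound 4 (0.36 log units; beyond the scatter) is a modest step beyond the scatter, while a 1.7-fold higher number from compound 1 to compound 4 (0.24 log units; within the scatter) stays within it, so compound 1 goes against any general claim that losing the ring raises the number.

Going by these compounds, whether a longer chain, such as hexyl, or a chain ending in an amine would behave like propyl remains open. Nothing available here explains the step from the 4-(dimethylamino)phenyl group to propyl.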